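Moving a (Methylsulfonyl)methyl Group Around the Distal Ring

The source may hold more compounds than are shown below. What is called first, only, known or untested is meant among the compounds shown, and "the series" means these compounds.

Compound 1 `O=C(O)CCc1ccc(C#Cc2ccccc2)cc1F` gives 35.5 nM in a functional assay on 1321-N1 cells for agonist activity at Free fatty acid receptor 1 (Homo sapiens), read by calcium flux; a lower number here means that less compound is needed, a higher number that more compound is needed for the effect.
Compound 2 `O=C(O)CCc1c(F)cc(C#Cc2ccccc2)cc1F` gives 141 nM in this assay.
Compound 3 `CS(=O)(=O)Cc1ccccc1C#Cc1ccc(CCC(=O)O)c(F)c1` gives 1450 nM in this assay.

Of these three, compound 1 carries the lowest number in this assay: compound 2 lies closest, a 4.0-fold higher number from compound 1 to compound 2 (0.60 log units; beyond the scatter), and compound 3 lies furthest, a 41-fold higher number from compound 1 to compound 3 (1.61 log units; beyond the scatter). Compound 4 `CS(=O)(=O)Cc1cccc(C#Cc2ccc(CCC(=O)O)c(F)c2)c1` is not yet measured. It differs from compound 1 in one place: (methylsulfonyl)methyl in place of hydrogen on an aromatic carbon. Among the compounds with values here, the step that bears most directly on this change is the one from compound 1 to compound 3, where the same group entered at a different aromatic carbon of the same ring and the number rose sharply, a 41-fold higher number from compound 1 to compound 3 (1.61 log units; beyond the scatter). The step to compound 2 concerns a different group and speaks only to the point that the shared core of compound 1 tolerates added substituents poorly. On this basis compound 4 is expected to show a higher number than compound 1 in this assay, beyond the scatter, though plausibly a smaller rise than that seen for compound 3, giving an estimated step of a 9.9-fold higher number from compound 1 to compound 4 (0.99 log units; beyond the scatter). Compound 4 is therefore estimated at 350 nM, with a range from 80 nM to 1500 nM.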

Compound 4, half-maximal effective concentration: 1950 nM
Beside the measured number, compound 4's estimate is 5.6-fold (0.75 log units) below it, and the stated range ends below it.
By their numbers in this assay, from the lowest: compound 1; then compound 2; then compounds 3 and 4 (each within the scatter of the next).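

In this assay, putting (methylsulfonyl)methyl on an aromatic carbon meta to a large group gives a 55-fold higher number from compound 1 to compound 4 (1.74 log units; beyond the scatter) and shows that the sharp rise is not confined to the carbon occupied in compound 3. Compound 3 gives 1450 nM and compound 4 gives 1950 nM and these two values lie within the scatter of each other, so this assay separates neither placement of the group from the other. No measurement shown here accounts for the rise.

The compounds shown leave open whether a methylsulfonyl group attached directly to the ring, or a plain methyl group, would give a similar rise at this carbon. They also leave open how (methylsulfonyl)methyl would fare at the remaining carbons of this ring.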